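From 4-Methoxyphenyl to 2-Aminophenyl in Compound 4

This account rests on a few compounds, and the source may have more. Where it says the series, first, only, none or still open, it means among the compounds named here.

Compound 1 `COC(=O)c1sc2cc(C#Cc3ccc(OC)cc3)cnc2c1N` is the anchor of this small series. In a functional assay on MCF7 cells (Homo sapiens) for inhibition, read by sulforhodamine B assay, with a stated time of 48 h (a higher number here means a weaker inhibitor of growth, a lower number a stronger inhibitor of growth), compound 1 gives 460 nM, the lowest number among the values shown. Compound 3 `COC(=O)c1sc2cc(C#Cc3ccsc3)cnc2c1N` gives 27700 nM in this assay. For compound 2 `COC(=O)c1sc2cc(C#Cc3ccccc3OC)cnc2c1N` this assay reports only a limit, > 47300 nM, rather than a number; the limit of > 47300 nM in this assay, at which 1 of the 3 values shown sits, marks this. The two measured steps away from compound 1 are both large: an at least 100-fold higher number from compound 1 to compound 2 (2.01 log units; beyond the scatter), and a 60-fold higher number from compound 1 to compound 3 (1.78 log units; beyond the scatter). Between compound 2 and compound 3 the step is an at least 1.7-fold lower number from compound 2 to compound 3 (0.23 log units; that floor lies within the scatter).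

Compound 4 `COC(=O)c1sc2cc(C#Cc3ccccc3N)cnc2c1N` has not yet been measured in this assay. It differs from compound 1 in one place: 2-aminophenyl in place of 4-methoxyphenyl on a triple-bonded carbon. The step from compound 1 to compound 2 bears most directly on this change, since both moves carry the substituent of the phenyl group from the 4-position to the 2-position, and that move was large and beyond the scatter. Compound 4 is therefore expected to give a much higher number than compound 1, with a step estimated at a 43-fold higher number from compound 1 to compound 4 (1.64 log units; beyond the scatter). The estimate for compound 4 is 20000 nM, in a range from 3000 nM to 100000 nM, with a real chance that this assay reports only a limit for compound 4.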

Compound 4, concentration for 50% growth inhibition: 4100 nM
Beside the measured number, compound 4's estimate is 4.9-fold (0.69 log units) above it, and the stated range covers the measured number.
By their numbers in this assay, from the lowest: compound 1; then compound 4; then compound 3. At a limit, above all of these: compound 2.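

Compound 4 shows that a substituted phenyl on this triple-bonded carbon need not lose all measurable growth inhibition, as amino in place of methoxy on an aromatic carbon gives an at least 11-fold lower number from compound 2 to compound 4 (1.06 log units; beyond the scatter). Compound 2 stands only at a limit in this assay: the limit of > 47300 nM in this assay, at which 1 of the 4 values shown sits. The 2-aminophenyl group still falls short of 4-methoxyphenyl, with an 8.9-fold higher number from compound 1 to compound 4 (0.95 log units; beyond the scatter), yet it improves on thiophen-3-yl, with a 6.8-fold lower number from compound 3 to compound 4 (0.83 log units; beyond the scatter), so the outcome at this position depends on the group itself and not only on the numbering of its substituent.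

What 4-aminophenyl would give on the same triple-bonded carbon remains open, so the compounds shown do not separate the amino group from its place on the ring. Whether 2-hydroxyphenyl or 2-(dimethylamino)phenyl would track compound 4 is open as well.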